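Compound 3: bromo in place of nitro

This account rests on a few compounds, and the source may have more. Where it says the series, first, only, none or still open, it means among the compounds named here.

In a functional assay on MDA-MB-231 cells (Homo sapiens) for cytotoxicity, read by MTT assay, with a stated time of 72 h (a lower number here means a stronger inhibitor, a higher number a weaker inhibitor), compound 1 `Nn1c(SCc2cccc([N+](=O)[O-])c2)nnc1-c1c[nH]c2ccccc12` gives 310 nM and compound 2 `Nn1c(SCc2ccc([N+](=O)[O-])cc2)nnc1-c1c[nH]c2ccccc12` gives 740 nM. Compound 2 therefore holds the higher of the two numbers, and its gap to compound 1 lies beyond the scatter. Compound 3 `Nn1c(SCc2ccc(Br)cc2)nnc1-c1c[nH]c2ccccc12` has bromo in place of nitro on an aromatic carbon, para to a large group: bromo in place of nitro on an aromatic carbon. For the measured compounds named here, no measured compound carries bromo, so the data hold no direct step for this change. A modest shift toward a lower number in this assay is expected, though not one beyond the scatter. Going by the values given here, the estimated step of a 1.6-fold lower number from compound 2 to compound 3 (0.22 log units; within the scatter) reflects that expectation and stays tentative with only two measured compounds. Compound 3 is expected at 450 nM, with an estimated range of 130 nM to 1500 nM.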

Compound 3, half-maximal inhibitory concentration: 71400 nM
Compound 3: the middle estimate sits 160-fold (2.20 log units) below what was measured; measured number above the stated range.
By their numbers in this assay, from the lowest: compound 1; then compound 2; then compound 3.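

Bromo in place of nitro on this aromatic carbon, para to a large group, is far from a neutral exchange in this assay and gives a 96-fold higher number from compound 2 to compound 3 (1.98 log units; beyond the scatter). For the compounds shown here, the earlier compounds all carry nitro on this ring, so this is the first sign that the group at this place, and not the shared core alone, can set the number in this assay. Nothing measured here accounts for the size of the step.

Going by these compounds, it remains open whether this loss belongs to bromo alone or would follow any replacement of nitro, and chloro, nitrile or an amine at the same place would help separate these cases. Also open, on these data alone, is whether bromo would give a similar result on the aromatic carbon that carries nitro in compound 1.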